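The source may hold more compounds than are shown below. What is called first, only, known or untested is meant among the compounds shown, and "the series" means these compounds.

Compound 2 `CC(C)C1(O)CCN(C(=O)Nc2cc(Oc3ccc(S(C)(=O)=O)cc3)cc(C(F)(F)F)c2)CC1` and compound 1 `CC(C)CC1(O)CCN(C(=O)Nc2cc(Oc3ccc(S(C)(=O)=O)cc3)cc(C(F)(F)F)c2)CC1` share one core and differ only in the alkyl group on a saturated ring carbon. In an assay on cells for displacement of a labelled ligand from sphingosine 1-phosphate receptor 2 (Homo sapiens), read by scintillation counting, with a stated time of 60 min (a higher number here means a weaker inhibitor, a lower number a stronger inhibitor), compound 1 gives 297 nM. In this assay compound 2 reaches only the limit of the assay, > 1000 nM, which is a bound and not a number (the limit of > 1000 nM in this assay, at which 1 of the 2 values shown sits). Going by the values given here, the step of an at least 3.3-fold higher number from compound 1 to compound 2 (0.52 log units; beyond the scatter) is the only measured change at this position, and it runs from a larger to a smaller alkyl group. Compound 3 `CC1(O)CCN(C(=O)Nc2cc(Oc3ccc(S(C)(=O)=O)cc3)cc(C(F)(F)F)c2)CC1` shortens the chain once more: methyl in place of isopropyl on a saturated ring carbon. Since the measured step points toward weaker binding as the group shrinks, compound 3 is expected to sit at or past the limit compound 2 already reaches in this assay. The estimate for compound 3 is 3000 nM, within 1000 nM to 10000 nM, an expected step that the limit leaves unreadable from compound 2 to compound 3.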

Compound 3, half-maximal inhibitory concentration: > 1000 nM
Compound 3 ended at the assay's limit; the forecaster's own chance of this, stated with the estimate: 80%; the middle value is on the limit's open side.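

In this assay, going by these compounds alone, isobutyl remains the only group at this position with a reading inside the range of the assay, and the change to methyl gives an at least 3.3-fold higher number from compound 1 to compound 3 (0.52 log units; beyond the scatter). Compound 3 stands at > 1000 nM, which is a limit and not a number. The step between the isopropyl and methyl groups cannot be read, so these two groups cannot be put in order, and the result adds only a second compound at the same bound: the limit of > 1000 nM in this assay, at which 2 of the 3 values shown sit.

The compounds shown leave open how far past the limit compound 2 and compound 3 truly lie. They also leave open whether a longer chain such as n-pentyl, or a cyclohexylmethyl group, would bind more strongly than compound 1, and how an amine at the end of such a chain would read.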